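This account rests on a few compounds, and the source may have more. Where it says the series, first, only, none or still open, it means among the compounds named here.

Three compounds have been measured so far:

Compound 1, `COc1cc(NC(=O)Nc2cc(Nc3ccc(F)c(Cl)c3)ncn2)cc(OC)c1`, gives 25.5% in a functional assay on NCI-H520 cells (Homo sapiens) for inhibition, read by MTT assay, with a stated time of 48 h, tested at 10 uM; a lower number here means less inhibition, a higher number more inhibition at the concentration tested (going by the name of the read-out).
Compound 2, `COc1cc(NC(=O)Nc2cc(Nc3cc(F)ccc3OC)ncn2)cc(OC)c1`, gives 38% in this assay.
Compound 3, `COc1cc(NC(=O)Nc2cc(Nc3cc(C(F)(F)F)ccc3OC)ncn2)cc(OC)c1`, gives 63% in this assay.

All three share the same core and differ only in the aryl group carried on a nitrogen on an aromatic ring. Compound 2 sits in the middle of the three numbers: above compound 1 by a number 12.5 percentage points higher from compound 1 to compound 2 (beyond the scatter) and below compound 3 by a number 25 percentage points higher from compound 2 to compound 3 (beyond the scatter), both steps beyond the scatter but modest in size.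

Compound 4, `COc1cc(NC(=O)Nc2cc(Nc3cc(C)cc(F)c3)ncn2)cc(OC)c1`, is the next compound to be measured. It differs from compound 2 in one place: 3-fluoro-5-methylphenyl in place of 5-fluoro-2-methoxyphenyl on a nitrogen on an aromatic ring.

Within the data shown here, of the two measured steps, the one from compound 1 to compound 2 bears most on this change, since it too swaps one whole aryl group for another, and it moved the number by a number 12.5 percentage points higher from compound 1 to compound 2 (beyond the scatter). The step from compound 2 to compound 3 only alters a single group on an otherwise unchanged aryl ring, so it says less here. Among the measured compounds shown here, no measured compound lacks the methoxy group or carries a methyl group, so the direction is uncertain; a modest step in either direction, or none beyond the scatter, is plausible.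

Compound 4 is therefore expected to give about 35% in this assay, within a range from 15% to 55%, an expected step of a number 3 percentage points lower from compound 2 to compound 4 (within the scatter).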

Compound 4, a percentage reported as inhibition, at one concentration (the size of the read-out at that concentration, not a potency): 24.5%
Compound 4: the middle estimate sits 10.5 percentage points above what was measured, within the range that was stated.
By their numbers in this assay, from the lowest: compounds 4 and 1 (each within the scatter of the next); then compound 2; then compound 3.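

The change to 3-fluoro-5-methylphenyl on the nitrogen gives a number 13.5 percentage points lower from compound 2 to compound 4 (beyond the scatter) in this assay, so the gain seen with 5-fluoro-2-methoxyphenyl does not carry over to just any aryl group holding a fluoro substituent. The a number 1 percentage points lower from compound 1 to compound 4 (within the scatter) shows that two differently substituted aryl groups, 3-fluoro-5-methylphenyl and 3-chloro-4-fluorophenyl, neither with a methoxy group, cannot be told apart here, and compound 2, which has a methoxy group, stands above both. No measurement available here explains these differences.

Each of these steps swaps a whole aryl group, so the part played by the methoxy group cannot be separated from that of the methyl or chloro group, or from the different placing of the fluoro group. The compounds shown also leave open how an aryl group carrying a methoxy group alone would behave, and whether an amine, a carboxylic acid or a longer alkoxy chain on this aryl ring would keep, raise or lower the number.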